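The source may report more compounds than this note shows. Statements on the series, on what has been measured and on what is new or still open speak of the compounds shown alone.

Compound 1 `O=C(NC/C=C\Cn1cc(F)c(=O)[nH]c1=O)c1ccccc1` — a functional assay on SW-620 cells (Homo sapiens) for cytotoxicity, read by MTT assay, with a stated time of 72 h; a lower number here means a stronger inhibitor, a higher number a weaker inhibitor: > 100000 nM, a limit of the assay.
Compound 2 `Cc1cn(C/C=C\CNC(=O)c2ccccc2)c(=O)[nH]c1=O` — this assay: > 100000 nM, likewise a limit.

Compound 2 therefore stands only at a limit in this assay, with no number of its own. Both values shown sit at the limit of > 100000 nM in this assay, at which 2 of the 2 values shown sit. Among the compounds with values here, the one measured step, a step that the two limits leave unreadable from compound 1 to compound 2, cannot be read from two limits. Compound 3 `Cc1cn(C/C=C\CNC(=O)c2ccc(F)cc2)c(=O)[nH]c1=O` differs from compound 2 by fluoro in place of hydrogen on an aromatic carbon. Within the data shown here, no measured step bears on that change, so no direction beyond the scatter can be expected. The step from compound 2 to compound 3 in this assay is estimated at a step that the limit leaves unreadable from compound 2 to compound 3. Compound 3 is expected to give 150000 nM in this assay, in the range 40000 nM to 600000 nM, most likely again only a limit.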

Compound 3, half-maximal inhibitory concentration: > 100000 nM
Compound 3 was reported as a limit; the forecaster's own chance of this, stated with the estimate: 85%; the middle value lies beyond the limit too.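

Within the data shown here, compound 2 and compound 3 both stand only at a limit in this assay and no step between them can be read. The compounds shown leave open whether phenyl to 4-fluorophenyl changes cytotoxicity at all.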